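This account rests on a few compounds, and the source may have more. Where it says the series, first, only, none or still open, it means among the compounds named here.

Three analogues built on a shared aryl urea core have been tested in a functional assay on KETR3 cells (Homo sapiens) for inhibition, read by MTT assay, with a stated time of 120 h; a higher number here means a weaker inhibitor, a lower number a stronger inhibitor. Compound 1 `CC(NC(=O)/C=C/Oc1ccc(NC(=O)Nc2cc(C(F)(F)F)ccc2Cl)cc1)c1ccccc1` gives 16400 nM in this assay. Compound 2 `CC(NC(=O)c1cccc(-c2ccc(NC(=O)Nc3ccc(Cl)c(C(F)(F)F)c3)cc2)c1)c1ccccc1` gives 6460 nM in this assay. For compound 3 `CNC(=O)/C(C)=C/c1ccc(NC(=O)Nc2ccc(Cl)c(C(F)(F)F)c2)cc1` this assay reports only a limit, > 50000 nM, so no exact number is known for it. Among the three results, compound 3 sits at the limit of > 50000 nM in this assay, at which 1 of the 3 values shown sits, and is the only one without a measured value. Compound 4 `CNC(=O)/C=C/c1ccc(NC(=O)Nc2ccc(Cl)c(C(F)(F)F)c2)cc1` differs from compound 3 in a single place: 2-(methylcarbamoyl)ethenyl in place of 2-(methylcarbamoyl)prop-1-en-1-yl on an aromatic carbon. Among the measured compounds shown here, no measured pair shows what this change does. A modest gain in potency is expected, so that the estimated step from compound 3 to compound 4 is an at least 1.6-fold lower number from compound 3 to compound 4 (0.22 log units; that floor lies within the scatter). Compound 4 is therefore expected to give about 30000 nM in this assay, within a range from 8000 nM to 80000 nM.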

Compound 4, half-maximal inhibitory concentration: 21200 nM
Beside the measured number, compound 4's estimate is 1.4-fold (0.15 log units) above it; measured number inside the range.
By their numbers in this assay, from the lowest: compound 2; then compounds 1 and 4 (each within the scatter of the next). At a limit, above all of these: compound 3.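

Among the compounds shown here, the pair gives the first comparison in this set that differs in one place: an at least 2.3-fold lower number from compound 3 to compound 4 (0.37 log units; beyond the scatter) comes with 2-(methylcarbamoyl)ethenyl in place of 2-(methylcarbamoyl)prop-1-en-1-yl, so the number responds to a small change in the group on this aromatic carbon. The full size of the step cannot be read, because compound 3 has only a limit and no exact number: the limit of > 50000 nM in this assay, at which 1 of the 4 values shown sits.

Still open, going by these compounds, is how other groups at this place would behave, such as a carboxylic acid, an amine or a longer chain ending in the same amide.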